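This account rests on a few compounds, and the source may have more. Where it says the series, first, only, none or still open, it means among the compounds named here.

Measured in a functional assay on OCI-Ly3 cells (Homo sapiens) for inhibition, read by CellTiter-Glo, with stated times of 48 h and 96 h; a higher number here means a weaker inhibitor of growth, a lower number a stronger inhibitor of growth:
- Compound 1 `CC(C)[C@H](NC(=O)c1ccccc1Br)C(=O)N1CCC[C@H]1C(=O)N[C@@H](CCCNC(=N)N)C(=O)CF`: 4240 nM
- Compound 2 `CC(C)[C@H](NC(=O)c1ccc(C(F)(F)F)cc1)C(=O)N1CCC[C@H]1C(=O)N[C@@H](CCCNC(=N)N)C(=O)CF`: 120 nM

In this assay, compound 2 has the lower of the two numbers, at 120 nM. Compound 3 `CC(C)[C@H](NC(=O)Nc1ccccc1)C(=O)N1CCC[C@H]1C(=O)N[C@@H](CCCNC(=N)N)C(=O)CF` has anilino in place of 4-(trifluoromethyl)phenyl on a carbonyl carbon. Going by the values given here, only one measured step bears on this. a 35-fold lower number from compound 1 to compound 2 (1.55 log units; beyond the scatter) shows that a change on this carbonyl carbon can be large, but no measured compound carries anilino. Compound 2 starts from the better end of that step, so a higher number is expected, an estimated 4.2-fold higher number from compound 2 to compound 3 (0.62 log units; beyond the scatter). The estimated value for compound 3 is 500 nM, with an expected range of 120 nM to 2500 nM.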

Compound 3, concentration for 50% growth inhibition: 1520 nM
Beside the measured number, compound 3's estimate is 3.0-fold (0.48 log units) below it; the measured number falls inside the stated range.
By their numbers in this assay, from the lowest: compound 2; then compound 3; then compound 1.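

With anilino on this carbonyl carbon there is a 13-fold higher number from compound 2 to compound 3 (1.10 log units; beyond the scatter), even though both groups carry one six-membered aromatic ring of carbon only, so having that ring here does not by itself set the number. Against the 2-bromophenyl group, anilino gives a 2.8-fold lower number from compound 1 to compound 3 (0.45 log units; beyond the scatter), which places compound 3 between the other two compounds. Nothing available explains this order.

The compounds shown change the ring's trifluoromethyl group and the anilino nitrogen together, so their separate contributions remain open. A plain phenyl on this carbonyl carbon would help to separate them.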